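Series notes: cytotoxicity of amide analogues, compound 4 pending

This account rests on a few compounds, and the source may have more. Where it says the series, first, only, none or still open, it means among the compounds named here.

Measured so far in an ADME assay on RAW264.7 cells (Mus musculus) for cytotoxicity, read by MTT assay, with a stated time of 48 h, tested at 50 uM; a higher number here means more inhibition at the concentration tested (going by the name of the read-out), a lower number less inhibition:
compound 1 `N=C1S/C(=C\c2ccc(OCc3ccccc3)cc2)C(=O)N1c1ncccn1` gives 26.6%
compound 2 `NC(=O)c1c(NC(=O)c2ccc(Cl)cc2)sc2c1CCN(C(=O)c1ccccc1)C2` gives 42.5%
compound 3 `NC(=O)c1c(NC(=O)c2ccc(Oc3ccccc3)cc2)sc2c1CCN(C(=O)c1ccccc1)C2` gives 4.71%

Compound 3 stands lowest of the three numbers in this assay; compound 1 is the nearest and compound 2 the furthest, both beyond the scatter. Among the compounds with values here, the only single-place step measured is a number 37.8 percentage points lower from compound 2 to compound 3 (beyond the scatter), a change on an aromatic carbon. Compound 4 `CC(C)(C)OC(=O)N1CCc2c(sc(NC(=O)c3ccc(Oc4ccccc4)cc3)c2C(N)=O)C1` differs from compound 3 by tert-butoxy in place of phenyl on a carbonyl carbon. Within the data shown here, no measured step touches the carbonyl carbon, so the one step on record gives no guide to this change, and no step beyond the scatter is expected in this assay. Compound 4 is estimated at 8%, with a range from -10% to 30%. The expected step is a number 3.3 percentage points higher from compound 3 to compound 4 (within the scatter), within the scatter.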

Compound 4, a percentage reported as inhibition, at one concentration (the size of the read-out at that concentration, not a potency): 26.9%
For compound 4 the middle estimate is 18.9 percentage points below the measured one; the range from low to high includes it.
By their numbers in this assay, from the lowest: compound 3; then compounds 1 and 4 (each within the scatter of the next); then compound 2.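

Tert-butoxy in place of phenyl on the carbonyl carbon gives a number 22.2 percentage points higher from compound 3 to compound 4 (beyond the scatter) in this assay, so the read-out responds at this position as well as at the aromatic carbon of the earlier step. Because the step swaps an aromatic ring for an acyclic group and also brings in an oxygen, it does not show which part of the change matters. No supporting data account for the step.

Open, as far as these compounds go, is how an amine or methoxy on this carbonyl carbon would read. Also open, from the compounds shown here alone, is whether tert-butoxy gives a similar step with chloro on the aromatic carbon.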